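Extending the ester chain of a quinazoline ester-amide series

The source may report more compounds than this note shows. Statements on the series, on what has been measured and on what is new or still open speak of the compounds shown alone.

Compound 1 `CCOC(=O)CCC(=O)N1CCN(CCCOc2cc3c(Nc4ccc(F)c(Cl)c4)ncnc3cc2OC)CC1` and compound 2 `CCCOC(=O)CCC(=O)N1CCN(CCCOc2cc3c(Nc4ccc(F)c(Cl)c4)ncnc3cc2OC)CC1` share one core and differ only in the ester chain. In a functional assay on A549 cells (Homo sapiens) for cytotoxicity, read by MTT assay, with a stated time of 24 h, tested at 10 uM (on this read-out lower numbers stand for a stronger effect and higher numbers for a weaker effect at the one concentration tested), compound 1 gives 77.6%, while compound 2 gives 95.1%. The step of a number 17.5 percentage points higher from compound 1 to compound 2 (beyond the scatter) is the only measured one, and it leaves compound 2 with the highest of the two numbers, its nearest neighbour being compound 1. Compound 3 `CCCCCCCCOC(=O)CCC(=O)N1CCN(CCCOc2cc3c(Nc4ccc(F)c(Cl)c4)ncnc3cc2OC)CC1` carries the same core with a longer ester chain; the change from compound 2 is pentyl in place of hydrogen on a saturated chain carbon, three bonds along the chain from an oxygen next to a carbonyl group. Among the measured compounds shown here, the one known step went in the direction of a weaker effect, but it is modest, and compound 2 already stands near the top of the scale, so a further rise is expected to be small or absent. Compound 3 is therefore expected to give 92%, within 68% to 110%, meaning an estimated step of a number 3.1 percentage points lower from compound 2 to compound 3 (within the scatter).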

Compound 3, a percentage reported as activity, at one concentration (the size of the read-out at that concentration, not a potency): 87.3%
Estimate against measurement, compound 3: 4.7 percentage points above; measured number inside the range.
By their numbers in this assay, from the lowest: compounds 1, 3 and 2 (each within the scatter of the next, the first and the last beyond it).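

In this assay, pentyl in place of hydrogen on a saturated chain carbon, three bonds along the chain from an oxygen next to a carbonyl group, gives a number 7.8 percentage points lower from compound 2 to compound 3 (within the scatter) and so does not extend the earlier step of a number 17.5 percentage points higher from compound 1 to compound 2 (beyond the scatter) in the same direction beyond the scatter. Hexyl in place of hydrogen at the carbon two bonds along the chain gives a number 9.7 percentage points higher from compound 1 to compound 3 (within the scatter) and so leaves compound 3 inseparable from both shorter esters, even though those two lie beyond the scatter of each other. Nothing at hand accounts for these numbers.

Going by these compounds, whether a butyl or hexyl ester would fall closer to compound 1 or to compound 2 remains open. So does the effect of replacing the ester with a carboxylic acid or an amide.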